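The source may hold more compounds than are shown below. What is called first, only, known or untested is meant among the compounds shown, and "the series" means these compounds.

Compound 1 `Cc1cnc(C(=O)Nc2cccc3ccc(C)nc23)cn1` and compound 2 `Cc1cnc(C(=O)Nc2ccc(Br)c3cccnc23)cn1` are both amides of a bicyclic amine; how the two cores differ is not broken down here. In a functional assay on PANC-1 cells (Homo sapiens) for inhibition, read by MTT assay, with a stated time of 72 h (a higher number here means a weaker inhibitor, a lower number a stronger inhibitor), compound 1 gives > 10000 nM, a limit of the assay rather than a number. In this assay compound 2 gives 6800 nM. Compound 3 `Cc1ccc2cccc(NC(=O)c3cnccn3)c2n1` comes from compound 1 by hydrogen in place of methyl on an aromatic carbon. In this assay compound 3 gives > 10000 nM, again a limit. The step that the two limits leave unreadable from compound 1 to compound 3 thus cannot be read because of the limit of > 10000 nM in this assay, at which 2 of the 3 values shown sit. Compound 4 `O=C(Nc1ccc(Br)c2cccnc12)c1cnccn1` comes from compound 2 by the same change, (hydrogen in place of methyl on an aromatic carbon). With that step unreadable, the expectation rests only on compound 2 giving 6800 nM in this assay. Compound 4 is expected to show a step of a 1.3-fold higher number from compound 2 to compound 4 (0.12 log units; within the scatter) in this assay. Compound 4 is thus estimated at 9000 nM, between 4000 nM and 20000 nM, in this assay.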

Compound 4, half-maximal inhibitory concentration: 7000 nM
For compound 4 the middle estimate is 1.3-fold (0.11 log units) above the measured one; low and high end bracket the measured number.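

In this assay, the change from 5-methylpyrazin-2-yl to pyrazin-2-yl on the core of compound 2 gives a 1.0-fold higher number from compound 2 to compound 4 (0.01 log units; within the scatter), so on this core the methyl can be lost without a measurable shift. On the core of compound 1 the same change cannot be read, because compound 1 and compound 3 both sit at a limit of the assay: the limit of > 10000 nM in this assay, at which 2 of the 4 values shown sit. The change has therefore been read on one core only, and these data do not show whether the result carries over to the other core.

Going by these compounds, whether a larger group at the same place, such as an amine, a carboxylic acid or a longer chain, would move the number remains open. Also open, on these data alone, is whether any such group would bring the core of compound 1 within the measurable range of this assay.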